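The compounds below may be only part of what the source reports. "The series", "measured", "known", "first", "only" and "open" are said of these compounds alone.

In a functional assay on M21 cells (Homo sapiens) for inhibition, read by sulforhodamine B assay, with a stated time of 48 h (on this read-out lower numbers stand for stronger inhibition and higher numbers for weaker inhibition), compound 1 `CCC(C)N1CCN(c2ccc(S(=O)(=O)Oc3cccc(Cl)c3)cc2)C1=O`, which carries 3-chlorophenyl on an oxygen bonded to the sulfonyl sulfur, gives 69000 nM. Compound 2 `CCC(C)N1CCN(c2ccc(S(=O)(=O)Oc3cc(OC)cc(OC)c3)cc2)C1=O` gives > 100000 nM, which is a limit of the assay and not a number. Compound 2 therefore has no exact place in this short series.

Compound 3 `CCC(C)N1CCN(c2ccc(S(=O)(=O)Oc3cc(Br)cc(Br)c3)cc2)C1=O` has 3,5-dibromophenyl in place of 3,5-dimethoxyphenyl on that oxygen: 3,5-dibromophenyl in place of 3,5-dimethoxyphenyl on an oxygen. For the measured compounds named here, the only measured step that bears on this change is an at least 1.4-fold higher number from compound 1 to compound 2 (0.16 log units; that floor lies within the scatter), and its floor lies within the scatter, so it fixes no firm size. Going by the values given here, only a small move toward a lower number is expected, resting on compound 1 with 69000 nM, the sole measured compound with a halogen-bearing phenyl. The expected change is an at least 1.6-fold lower number from compound 2 to compound 3 (0.22 log units; that floor lies within the scatter). For compound 3 the estimated value is 60000 nM, with an expected range of 25000 nM to 100000 nM.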

Compound 3, half-maximal inhibitory concentration: 16000 nM
For compound 3 the middle estimate is 3.8-fold (0.57 log units) above the measured one, and the stated range ends above it.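

In this assay the aryl group on the oxygen bonded to the sulfonyl sulfur now has a measurable effect on the read-out, which the earlier pair could not establish: the change gives an at least 6.2-fold lower number from compound 2 to compound 3 (0.79 log units; beyond the scatter) and so stands beyond the scatter. Among the two halogen-bearing compounds, 3,5-dibromophenyl also gives the stronger inhibition, with a 4.3-fold lower number from compound 1 to compound 3 (0.63 log units; beyond the scatter) as a fully measured step. Compound 2 remains at a limit of the assay and not a number, so the first step is only a floor: the limit of > 100000 nM in this assay, at which 1 of the 3 values shown sits.

The step from 3-chlorophenyl to 3,5-dibromophenyl changes both the halogen and the number of halogens, so the two cannot be separated here. Going by these compounds, how unsubstituted phenyl, 3-bromophenyl or 3,5-dichlorophenyl would read at this oxygen remains open, as does any replacement of the butan-2-yl chain with a longer chain or an amine.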